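The compounds below may be only part of what the source reports. "The series", "measured", "known", "first", "only" and "open" are said of these compounds alone.

Working notes on the series.

Three compounds have numbers in a functional assay on MCF7 cells (Homo sapiens) for antiproliferative activity, tested at 1 uM; on this read-out higher numbers stand for more inhibition at the one concentration tested (going by the name of the read-out) and lower numbers for less inhibition. Compound 1 `CCOC(=O)c1ccc(CO/N=C/c2c(C)nn(C)c2Oc2ccc(Cl)cc2)cc1` gives 33.9%, and on the numbers shown it stands at the top of the three. Compound 3 `Cc1nn(C)c(Oc2ccccc2)c1/C=N/OCc1cccc(-c2ccccc2)c1C` gives 24.4% in this assay, which lies within the scatter of compound 1, so no order between the two is claimed. Within the data shown here, compound 2 `CCOC(=O)c1ccc(CO/N=C/c2c(C)nn(-c3ccccc3)c2Oc2ccc(Cl)cc2)cc1` gives 12% in this assay; here the step is a number 21.9 percentage points lower from compound 1 to compound 2 (beyond the scatter), the one change with a phenyl in place of methyl on an aromatic nitrogen of the shared core.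

Compound 4 `Cc1ccc(CO/N=C/c2c(C)nn(C)c2Oc2ccc(Cl)cc2)cc1` is not yet measured. It differs from compound 1 as follows: methyl in place of ethoxycarbonyl on an aromatic carbon. Among the measured compounds shown here, this change sits on the benzylic ring at the far end of the molecule, not on the core nitrogen where the one measured step was taken. For the measured compounds named here, no measured pair alters the ethoxycarbonyl, so nothing in the present data bears directly on this change; the step from compound 1 to compound 2 concerns a different place and gives no guide to the size or direction here. The default expectation is therefore a step within the scatter, with a wide range to allow for either direction.

Compound 4 is expected to give about 28% in this assay, between 8% and 48%. The expected step from compound 1 is a number 5.9 percentage points lower from compound 1 to compound 4 (within the scatter), within the scatter.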

Compound 4, a percentage reported as inhibition, at one concentration (the size of the read-out at that concentration, not a potency): 30.7%
Compound 4: middle estimate off by 2.7 percentage points, on the low side; the measured number falls inside the stated range.
By their numbers in this assay, from the lowest: compound 2; then compounds 3, 4 and 1 (each within the scatter of the next).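

Among these compounds, the first measured swap at this place, on an aromatic carbon para to a large group, reads in this assay as a number 3.2 percentage points lower from compound 1 to compound 4 (within the scatter). Among the compounds shown here, this single pair therefore does not separate the ethoxycarbonyl, with its hydrogen-bond acceptors and double bond outside aromatic rings, from a methyl that carries no hydrogen-bond acceptor, whereas the only earlier step, on the aromatic nitrogen of the shared core, was a number 21.9 percentage points lower from compound 1 to compound 2 (beyond the scatter) and lay beyond the scatter. No measurement is at hand that would account for this result at the level of mechanism.

The compounds shown leave open whether a carboxylic acid, an amine or a longer chain on this aromatic carbon would also stay within the scatter of compound 1, since one pair gives only two points at this place. They also leave open whether the same swap would read alike with phenyl on the aromatic nitrogen, as in compound 2, where the number is already low and a step in either direction could look different.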